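Chloro for hydrogen on the shared core: an expected small step

A few compounds are considered here, and "the series" means these few. Any claim that something is new, unique, unknown or untested is made for them only; others in the source may bear on it.

Compound 3 `CN(C)CN1C(=O)C(=O)c2ccccc21` gives 65600 nM in a functional assay on MDA-MB-231 cells (Homo sapiens) for cytotoxicity, read by sulforhodamine B assay, with a stated time of 48 h (a lower number here means a stronger inhibitor of growth, a higher number a weaker inhibitor of growth), the second highest of the three numbers. Compound 1 `CN(C)CN1C(=O)C(=O)c2c(Br)cccc21` gives 93700 nM, and compound 2 `CCN(CC)CN1C(=O)C(=O)c2c(Cl)cccc21` gives 44500 nM; both values lie within the scatter of compound 3. Compound 4 `CN(C)CN1C(=O)C(=O)c2c(Cl)cccc21` differs from compound 3 by chloro in place of hydrogen on an aromatic carbon. Within the data shown here, the only measured step that bears on this is the removal of a bromo from the same position, a 1.4-fold lower number from compound 1 to compound 3 (0.15 log units; within the scatter), a change too small to count. Putting a chloro on is the mirror of that step, so compound 4 is expected to move a 1.1-fold higher number from compound 3 to compound 4 (0.06 log units; within the scatter), with no change beyond the scatter. Compound 4 is therefore estimated at 75000 nM, with a range from 35000 nM to 160000 nM.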

Compound 4, concentration for 50% growth inhibition: 138000 nM
Compound 4: middle estimate off by 1.8-fold (0.26 log units), on the low side; low and high end bracket the measured number.
By their numbers in this assay, from the lowest: compounds 2, 3, 1 and 4 (each within the scatter of the next, the first and the last beyond it).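

In this assay, among these compounds, chloro in place of hydrogen on this aromatic carbon gives a 2.1-fold higher number from compound 3 to compound 4 (0.32 log units; beyond the scatter), the first step at this position to pass the scatter, while chloro in place of bromo gives a 1.5-fold higher number from compound 1 to compound 4 (0.17 log units; within the scatter) and cannot be told apart from no change. With the chloro kept, dimethylamino in place of diethylamino gives a 3.1-fold higher number from compound 2 to compound 4 (0.49 log units; beyond the scatter), so the amine also counts in this series. Nothing measured here offers a cause for these steps. Still open, going by these compounds, is how fluoro or methoxy would behave on this aromatic carbon, and how morpholine would compare in place of dimethylamino.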